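Amine variation on the shared core: compound 3

The source may hold more compounds than are shown below. What is called first, only, known or untested is meant among the compounds shown, and "the series" means these compounds.

Measured so far in an assay on CHO-K1 cells for antagonist activity at adenosine receptor A1 (Homo sapiens), read by a beta-galactosidase reporter, with stated times of 15 min and 6 h; on this read-out lower numbers stand for stronger inhibition and higher numbers for weaker inhibition:
compound 1 `Nc1nc(-c2ccco2)nc2sc(CNC3CC3)cc12` gives 1890 nM
compound 2 `Nc1nc(-c2ccco2)nc2sc(CN3CCC(F)CC3)cc12` gives 740 nM

Going by the values given here, compound 2 holds the lowest of the two numbers recorded in this assay; its nearest neighbour is compound 1, and the single step between them, a 2.6-fold lower number from compound 1 to compound 2 (0.41 log units; beyond the scatter), lies beyond the scatter and is modest.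

Compound 3 `Nc1nc(-c2ccco2)nc2sc(CN3CC=CC3)cc12` is not yet measured. It differs from compound 2 by a group of 5 heavy atoms (4 carbon, 1 nitrogen; one five-membered non-aromatic ring with 1 hetero atom) in place of a group of 7 heavy atoms (5 carbon, 1 nitrogen, 1 fluorine; one six-membered non-aromatic ring with 1 hetero atom), on a saturated chain carbon bound to an aromatic carbon. Among the compounds with values here, only the step of a 2.6-fold lower number from compound 1 to compound 2 (0.41 log units; beyond the scatter) bears on this change, and it concerns a different exchange at the same saturated chain carbon: cyclopropylamino replaced by 4-fluoropiperidin-1-yl. Nothing recorded compares a six-membered non-aromatic ring amine with a five-membered non-aromatic ring carrying one double bond outside aromatic rings, so no direction can be read from the data with confidence. The expected step in this assay is therefore small, a 1.4-fold higher number from compound 2 to compound 3 (0.13 log units; within the scatter), likely within the scatter or tending toward a slightly higher number. Compound 3 is estimated at 1000 nM, with a range from 400 nM to 2500 nM.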

Compound 3, inhibition constant: 290 nM
Compound 3: the middle estimate sits 3.4-fold (0.54 log units) above what was measured; the whole stated range lies above it.
By their numbers in this assay, from the lowest: compound 3; then compound 2; then compound 1.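

In this assay the group on the saturated chain carbon bound to an aromatic carbon has further room below the value of the 4-fluoropiperidin-1-yl compound: the five-membered non-aromatic ring with one double bond outside aromatic rings gives a further step beyond the scatter (a 2.6-fold lower number from compound 2 to compound 3 (0.41 log units; beyond the scatter)) and a larger one against the cyclopropylamino compound (a 6.5-fold lower number from compound 1 to compound 3 (0.81 log units; beyond the scatter)). Compound 3 now holds the lowest of the three numbers, and heavy-atom count does not order the series: the first step alone ran from the smaller group to the larger one with a lower number, while compound 3 goes against that reading, its group being smaller than that of compound 2. No measured evidence accounts for this step at this position.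

Ring size and the double bond change together here, so pyrrolidin-1-yl, the same five-membered ring without the double bond, would be the direct comparison with compound 3, and plain piperidin-1-yl would do the same for the fluorine of compound 2. Also open, as far as these compounds go, is how far the trend holds for an open-chain amine such as diethylamino or for a ring with a second hetero atom such as morpholin-4-yl.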